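The source may report more compounds than this note shows. Statements on the series, on what has been measured and on what is new or still open speak of the compounds shown alone.

Compounds measured so far in a functional assay on MCF7 cells (Homo sapiens) for inhibition, read by sulforhodamine B assay; on this read-out higher numbers stand for weaker inhibition and lower numbers for stronger inhibition:
compound 1 `O=C1C=C(Nc2ccccc2F)C(=O)c2c1nc1n2[C@H]2OC[C@@H](O)[C@H]2OC1` — 3640 nM
compound 2 `O=C1C(N2CCC2)=CC(=O)c2c1nc1n2[C@H]2OC[C@@H](O)[C@H]2OC1` — > 16000 nM
compound 3 `O=C1C(NCc2ccccc2)=CC(=O)c2c1nc1n2[C@H]2OC[C@@H](O)[C@H]2OC1` — > 8000 nM

For the measured compounds named here, compound 1 is the only compound of the three with a number in this assay. For compound 2 the value > 16000 nM is a limit of the assay, not a number (the limit of > 16000 nM in this assay, at which 1 of the 3 values shown sits). For compound 3 the value > 8000 nM is likewise a limit (the limit of > 8000 nM in this assay, at which 1 of the 3 values shown sits). The step that the two limits leave unreadable from compound 2 to compound 3 therefore cannot be sized.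

Compound 4 `O=C1C=C(N2CCCC2)C(=O)c2c1nc1n2[C@H]2OC[C@@H](O)[C@H]2OC1` differs from compound 1 by pyrrolidin-1-yl in place of (2-fluorophenyl)amino on a double-bonded ring carbon. Going by the values given here, no measured step carries this same change. The nearest comparison is compound 2, which carries azetidin-1-yl on a double-bonded ring carbon and whose result is only a limit. Compound 1, with (2-fluorophenyl)amino at that place, gives a number. On this basis a loss of potency is expected in this assay from compound 1 to compound 4, of about a 3.3-fold higher number from compound 1 to compound 4 (0.52 log units; beyond the scatter). Compound 4 is estimated at 12000 nM, in the range 4000 nM to 40000 nM, with a fair chance that only a limit is returned.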

Compound 4, half-maximal inhibitory concentration: > 16000 nM
Compound 4 was reported as a limit (the forecaster's own chance of this, stated with the estimate: 55%); middle value at least 1.3-fold (0.12 log units) away from the limit.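

In this assay, for the compounds shown here, pyrrolidin-1-yl in place of (2-fluorophenyl)amino on the double-bonded ring carbon gives an at least 4.3-fold higher number from compound 1 to compound 4 (0.64 log units; beyond the scatter), the one step with a readable size, while the step between the two other limit compounds cannot be read. Compound 4 returns only a limit, > 16000 nM: the limit of > 16000 nM in this assay, at which 2 of the 4 values shown sit.

The change removes the six-membered aromatic ring and the hydrogen-bond donor together, so this step alone cannot assign the loss to either feature. Going by these compounds, whether the ring, the donor or the fluorine carries the activity of compound 1 stays open. Also open, on these data alone, is what phenylamino without the fluorine, N-methyl-(2-fluorophenyl)amino or morpholin-4-yl would give at this place on the core of compound 1.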